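TRPV1 antagonist series: ring size change at the amino-substituted pyridine

A few compounds are considered here, and "the series" means these few. Any claim that something is new, unique, unknown or untested is made for them only; others in the source may bear on it.

Measured so far:
compound 1 `CC(C(=O)NCc1ccc(C(F)(F)F)nc1Nc1ccc(F)cc1)c1ccc(NS(C)(=O)=O)c(F)c1` 39.2 nM
compound 2 `CC(C(=O)NCc1ccc(C(F)(F)F)nc1NCc1ccc(Cl)cc1)c1ccc(NS(C)(=O)=O)c(F)c1` 65.7 nM
compound 3 `CC(C(=O)NCc1ccc(C(F)(F)F)nc1N1CCC(C)(C)CC1)c1ccc(NS(C)(=O)=O)c(F)c1` 0.3 nM

In a functional assay on CHO-K1 cells for antagonist activity at transient receptor potential cation channel subfamily V member 1 (Homo sapiens), read by FLIPR (on this read-out lower numbers stand for stronger inhibition and higher numbers for weaker inhibition), compound 3 stands lowest of the three; compound 1 and compound 2 give far higher numbers, with a 130-fold lower number from compound 1 to compound 3 (2.12 log units; beyond the scatter) and a 220-fold lower number from compound 2 to compound 3 (2.34 log units; beyond the scatter) both large, while a 1.7-fold higher number from compound 1 to compound 2 (0.22 log units; within the scatter) lies within the scatter. Compound 4 `CC(C(=O)NCc1ccc(C(F)(F)F)nc1N1CCCCCCC1)c1ccc(NS(C)(=O)=O)c(F)c1` carries the change (a group of 8 heavy atoms (7 carbon, 1 nitrogen; one eight-membered non-aromatic ring with 1 hetero atom) in place of a group of 8 heavy atoms (7 carbon, 1 nitrogen; one six-membered non-aromatic ring with 1 hetero atom), on an aromatic carbon). Among the measured compounds shown here, no measured step tests this ring change directly; the large steps to compound 3 only show that the saturated ring amine is where the low numbers are found. For compound 4 in this assay a step of a 3.3-fold higher number from compound 3 to compound 4 (0.52 log units; beyond the scatter) is expected, toward a somewhat higher number, with a fair chance it lies within the scatter. The estimate for compound 4 is 1 nM, between 0.2 nM and 5 nM.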

Compound 4, inhibition constant: 0.7 nM
Compound 4: middle estimate off by 1.4-fold (0.15 log units), on the high side, within the range that was stated.
By their numbers in this assay, from the lowest: compound 3; then compound 4; then compounds 1 and 2 (each within the scatter of the next).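

The step of a 2.3-fold higher number from compound 3 to compound 4 (0.37 log units; beyond the scatter) in this assay is modest, so low numbers at this position are not confined to 4,4-dimethylpiperidin-1-yl. Both a 56-fold lower number from compound 1 to compound 4 (1.75 log units; beyond the scatter) and a 94-fold lower number from compound 2 to compound 4 (1.97 log units; beyond the scatter) are large, so the low numbers now hold for two saturated ring amines, not one. No measured evidence speaks to the reason for these steps.

From the compounds shown here alone, whether pyrrolidin-1-yl or morpholin-4-yl keeps these low numbers stays open. Unsubstituted piperidin-1-yl also stays open, so the effects of ring size and the two methyl groups remain unseparated between compound 3 and compound 4.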